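A 3-nitrophenyl swap and growth inhibition in MCF7 cells

The source may hold more compounds than are shown below. What is called first, only, known or untested is meant among the compounds shown, and "the series" means these compounds.

Measured in a functional assay on MCF7 cells (Homo sapiens) for cytotoxicity, read by sulforhodamine B assay; a higher number here means a weaker inhibitor of growth, a lower number a stronger inhibitor of growth:
Compound 1 `CC1=CC[C@@H]([C@@](C)(O)CCCC(C)(C)NC(=S)NN)CC1`: 84200 nM
Compound 2 `CC1=CC[C@@H]([C@@](C)(O)CCCC(C)(C)NC(=S)N/N=C\c2ccc(C)cc2)CC1`: > 100000 nM
Compound 3 `CC1=CC[C@@H]([C@@](C)(O)CCCC(C)(C)NC(=S)N/N=C\c2ccc(O)cc2)CC1`: 21200 nM

The entry for compound 2, > 100000 nM, is a limit of the assay and not a number. Of the two actual numbers, compound 3 has the lower at 21200 nM. Its nearest neighbour is compound 1 at 84200 nM, and the gap between them is a 4.0-fold lower number from compound 1 to compound 3 (0.60 log units; beyond the scatter).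

Compound 4 `CC1=CC[C@@H]([C@@](C)(O)CCCC(C)(C)NC(=S)N/N=C\c2cccc([N+](=O)[O-])c2)CC1` has not yet been measured. It carries 3-nitrophenyl in place of 4-hydroxyphenyl on a carbon with a double bond to nitrogen.

The closest measured change is an at least 4.7-fold lower number from compound 2 to compound 3 (0.67 log units; beyond the scatter), with hydroxy in place of methyl on an aromatic carbon. The aromatic group bearing methyl gave an at least 1.1-fold higher number from compound 1 to compound 2 (0.07 log units; that floor lies within the scatter), whereas the one bearing hydroxy gave the lower number noted above. Within the data shown here, only these two aromatic examples are available, and no measured compound carries a nitro group.

With an at least 4.7-fold lower number from compound 2 to compound 3 (0.67 log units; beyond the scatter) as the main guide, and with compound 4 lacking hydroxy, a higher number than for compound 3 is expected. The expected step is a 2.1-fold higher number from compound 3 to compound 4 (0.33 log units; beyond the scatter). Compound 4 is estimated at 45000 nM, with an expected range of 15000 nM to 100000 nM.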

Compound 4, concentration for total growth inhibition: 18300 nM
For compound 4 the middle estimate is 2.5-fold (0.39 log units) above the measured one, and the stated range covers the measured number.
By their numbers in this assay, from the lowest: compounds 4 and 3 (each within the scatter of the next); then compound 1. At a limit, above all of these: compound 2.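

In this assay, the step with 3-nitrophenyl in place of 4-hydroxyphenyl on a carbon with a double bond to nitrogen is a 1.2-fold lower number from compound 3 to compound 4 (0.06 log units; within the scatter), so this position tolerates the exchange of one group for the other without a change that can be told from the scatter. The entering group has 0 hydrogen-bond donors, yet the step to it from 4-methylphenyl is an at least 5.4-fold lower number from compound 2 to compound 4 (0.73 log units; beyond the scatter), which shows that among the compounds shown, a hydroxy group is not the only feature that separates these values from the one for compound 2. Compound 2 enters this comparison only through a limit of the assay, which is not a number: the limit of > 100000 nM in this assay, at which 1 of the 4 values shown sits.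

The swap alters both the group and its printed ring number in a single step, so the compounds shown cannot tell whether the nitro group itself or its placement matters, and 4-nitrophenyl or 3-hydroxyphenyl would separate the two. They also leave open how an aromatic ring carrying an amine or a carboxylic acid would read here, or whether a longer chain in place of the aromatic group would hold these values.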